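The compounds below may be only part of what the source reports. "The series", "measured", "known", "first", "only" and "open" are said of these compounds alone.

Values in a physicochemical assay for lipophilicity, read by HPLC, at pH 3.0; a higher number here means a more lipophilic compound, a lower number a more polar compound:
compound 1 `Cc1csc(NC(=O)c2cc(C(C)(C)C)nn2Cc2ccccc2)n1`: 4.7
compound 2 `COc1ccc(C(=O)Nc2nc(CN)cs2)cc1`: 0.9

Compound 1 has the higher of the two numbers; compound 2 sits far lower, a gap well beyond the scatter. Within the data shown here, the compounds share nothing close enough for a single-point step, so no measured step is available.

Compound 3 `CC(C)(C)c1cc(C(=O)Nc2ccccn2)n(Cc2ccccc2)n1` differs from compound 1 in one place: pyridin-2-yl in place of 4-methyl-1,3-thiazol-2-yl on an amide-type nitrogen. The expected change is a modest drop in this assay, beyond the scatter but not large, in the direction of compound 2; the estimated step is a number 0.70 log units lower from compound 1 to compound 3 (beyond the scatter). Compound 3 is expected to give about 4, within 3.4 to 4.6.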

Compound 3, distribution coefficient: 4.5
The estimate for compound 3 lay 0.50 log units below the measured number; the measured number falls inside the stated range.
By their numbers in this assay, from the lowest: compound 2; then compounds 3 and 1 (each within the scatter of the next).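

In this assay the change from 4-methyl-1,3-thiazol-2-yl to pyridin-2-yl on the amide-type nitrogen reads as a number 0.20 log units lower from compound 1 to compound 3 (within the scatter) and gives the series its first single-place comparison. On the core of compound 1, these two rings are not told apart by this read-out. No measurement at hand bears on the reason for this.

Open, on these data alone, is whether a pyridin-2-yl carrying an amine or a carboxylic acid would also stay within the scatter of compound 3. A methyl-free 1,3-thiazol-2-yl would show what the methyl contributes on this nitrogen.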